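A few compounds are considered here, and "the series" means these few. Any claim that something is new, unique, unknown or untested is made for them only; others in the source may bear on it.

Among the measured compounds shown here, compound 2 `O=C1N=C(N2CCC[C@H]2C(=O)Nc2ccc3ncnc(Nc4cccc(Cl)c4)c3c2)S/C1=C/c1cccnc1Cl` gives the lower of the two numbers measured so far: in a functional assay on HepG2 cells (Homo sapiens) for antiproliferative activity, read by MTT assay (on this read-out higher numbers stand for weaker inhibition and lower numbers for stronger inhibition), compound 2 gives 6400 nM, while compound 1 `COc1ccc(/C=C2/SC(N3CCC[C@H]3C(=O)Nc3ccc4ncnc(Nc5cccc(Cl)c5)c4c3)=NC2=O)cc1` gives 19000 nM in this assay. For the measured compounds named here, the single measured step, a 3.0-fold lower number from compound 1 to compound 2 (0.47 log units; beyond the scatter), is the only one that bears on the change now in question. Compound 3 `COc1ccccc1/C=C1/SC(N2CCC[C@H]2C(=O)Nc2ccc3ncnc(Nc4cccc(Cl)c4)c3c2)=NC1=O` differs from compound 2 by 2-methoxyphenyl in place of 2-chloropyridin-3-yl on a double-bonded chain carbon bound to a double-bonded ring carbon. This change brings back a methoxyphenyl group, though not the same isomer as in compound 1, so the step is expected to run back toward the number of compound 1 and partly undo the gain seen in a 3.0-fold lower number from compound 1 to compound 2 (0.47 log units; beyond the scatter); a modest rise beyond the scatter is estimated as a 1.9-fold higher number from compound 2 to compound 3 (0.27 log units; within the scatter). On that basis compound 3 is estimated to give 12000 nM in this assay, with a range from 5000 nM to 30000 nM.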

Compound 3, half-maximal inhibitory concentration: 22100 nM
Compound 3: the middle estimate sits 1.8-fold (0.27 log units) below what was measured, and the stated range covers the measured number.
By their numbers in this assay, from the lowest: compound 2; then compounds 1 and 3 (each within the scatter of the next).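

In this assay, the step of a 3.5-fold higher number from compound 2 to compound 3 (0.54 log units; beyond the scatter) shows that a second methoxyphenyl group, on a double-bonded chain carbon bound to a double-bonded ring carbon, also reads above 2-chloropyridin-3-yl, so compound 2 stands apart from both methoxyphenyl compounds. The step of a 1.2-fold higher number from compound 1 to compound 3 (0.07 log units; within the scatter) adds that 2-methoxyphenyl and 4-methoxyphenyl cannot be told apart here, so among these two isomers the place of the methoxy group leaves no mark on the read-out. Nothing at hand gives a reason for the difference between 2-chloropyridin-3-yl and the methoxyphenyl groups.

Open, as far as these compounds go, is whether the lower number of compound 2 follows the chlorine or the ring nitrogen, which 2-chlorophenyl and unsubstituted pyridin-3-yl would separate. From the compounds shown here alone, how a dimethylamino group or a carboxylic acid on the phenyl ring would read also stays open.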